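Replacing methoxy with piperazinyl on a fused core

The source may report more compounds than this note shows. Statements on the series, on what has been measured and on what is new or still open speak of the compounds shown alone.

Measured compounds:
compound 1 `CNc1nc(NCCCN(C)C)c2sc(-c3ccc(C(F)(F)F)cc3)cc2n1`: 177 ug/mL
compound 2 `CN(C)CCCNc1nc(N)nc2cc(-c3ccc(C(F)(F)F)cc3)sc12`: 148 ug/mL
compound 3 `COc1nc(NCCCN(C)C)c2sc(-c3ccc(C(F)(F)F)cc3)cc2n1`: < 5 ug/mL

In a physicochemical assay for solubility, in phosphate buffer, at pH 6.5 (on this read-out lower numbers stand for lower solubility and higher numbers for higher solubility), compound 1 gives 177 ug/mL and compound 2 gives 148 ug/mL. The value for compound 3, < 5 ug/mL, is a limit of this assay rather than a number, described by the limit of < 5 ug/mL in this assay, at which 1 of the 3 values shown sits. Compound 3 thus stands at the bottom of the values shown: the step of an at least 35-fold lower number from compound 1 to compound 3 (1.54 log units; beyond the scatter) and the step of an at least 29-fold lower number from compound 2 to compound 3 (1.47 log units; beyond the scatter) are both large, whereas a 1.2-fold lower number from compound 1 to compound 2 (0.08 log units; within the scatter) is not.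

Compound 4 `CN(C)CCCNc1nc(N2CCNCC2)nc2cc(-c3ccc(C(F)(F)F)cc3)sc12` differs from compound 3 in one place: piperazin-1-yl in place of methoxy on an aromatic carbon. The two large steps in which methoxy replaced a nitrogen-linked group bear on this change, since here a nitrogen-linked group replaces methoxy. A large rise in this assay is therefore expected, an at least 40-fold higher number from compound 3 to compound 4 (1.60 log units; beyond the scatter), with the exact size uncertain since compound 3 has only a limit. Compound 4 is estimated at 200 ug/mL, with a range from 50 ug/mL to 600 ug/mL.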

Compound 4, solubility: 178 ug/mL
Compound 4: middle estimate off by 1.1-fold (0.05 log units), on the high side; the measured number falls inside the stated range.
By their numbers in this assay, from the lowest: compounds 2, 1 and 4 (each within the scatter of the next). At a limit, below all of these: compound 3.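

In this assay, the step of an at least 35-fold higher number from compound 3 to compound 4 (1.55 log units; beyond the scatter) shows that this carbon, between two ring nitrogen atoms, can carry a six-membered non-aromatic ring linked through nitrogen, not only the small amino and methylamino groups. Enlarging the nitrogen-linked group to piperazin-1-yl opens no gap beyond the scatter, as the steps of a 1.2-fold higher number from compound 2 to compound 4 (0.08 log units; within the scatter) and a 1.0-fold higher number from compound 1 to compound 4 (0.00 log units; within the scatter) show. The first of these steps gives only a bound on the size of the change, because compound 3 stands at a limit: the limit of < 5 ug/mL in this assay, at which 1 of the 4 values shown sits.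

On these data alone, it remains open whether morpholin-4-yl, whose ring holds an oxygen in place of the second nitrogen, would stay level with compound 1, compound 2 and compound 4. The same is open for a carbon-linked group such as an ethyl chain at this position.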